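The source may report more compounds than this note shows. Statements on the series, on what has been measured and on what is new or still open speak of the compounds shown alone.

Measured compounds:
compound 1, `O=S(=O)(c1ccccc1)c1cn(C2CCCNC2)c2ncccc12`: 47 nM
compound 2, `CN1CCCC(n2cc(S(=O)(=O)c3cccc(F)c3)c3cccnc32)C1`: 306 nM
compound 3, `O=S(=O)(c1cc(Cl)cc(Cl)c1)c1cn(C2CCCNC2)c2ncccc12`: 297 nM

In a functional assay on HeLa cells for agonist activity at 5-hydroxytryptamine receptor 6 (Homo sapiens), read by cAMP accumulation and immunoassay (a higher number here means that more compound is needed for the effect, a lower number that less compound is needed), compound 3 holds the second highest of the three numbers. Its nearest neighbour is compound 2, whose number lies within the scatter of that of compound 3, so no order between the two can be read. Compound 1 sits further off, and the step of a 6.3-fold higher number from compound 1 to compound 3 (0.80 log units; beyond the scatter) is beyond the scatter.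

The next compound, compound 4, `CN1CCCC(n2cc(S(=O)(=O)c3cc(Cl)cc(Cl)c3)c3cccnc32)C1`, carries methyl in place of hydrogen on an amine nitrogen in a ring. Among the measured compounds shown here, no measured step isolates this change. For the measured compounds named here, the only measured compound with a methyl on the ring nitrogen is compound 2, and it differs from compound 1 in two places, the methyl and a fluorine on the phenyl, so the pair shows only the combined outcome: compound 2 gives a higher number than compound 1, well beyond the scatter. As far as these compounds go, whether the methyl alone contributes is unknown.

On this thin basis a small rise is expected, of the order of a 1.7-fold higher number from compound 3 to compound 4 (0.23 log units; within the scatter), which may still fall within the scatter. For compound 4 the expected value in this assay is 500 nM, with a range from 200 nM to 1500 nM.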

Compound 4, half-maximal effective concentration: 38.7 nM
Compound 4: middle estimate off by 13-fold (1.11 log units), on the high side; the whole stated range lies above it.
By their numbers in this assay, from the lowest: compounds 4 and 1 (each within the scatter of the next); then compounds 3 and 2 (each within the scatter of the next).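

In this assay, among the compounds shown here, methyl in place of hydrogen on the amine nitrogen in the ring now has a step of its own, a 7.7-fold lower number from compound 3 to compound 4 (0.89 log units; beyond the scatter), where the earlier compounds gave only a combined outcome of the methyl and a fluorine. With 1-methylpiperidin-3-yl held fixed, 3,5-dichlorophenyl in place of 3-fluorophenyl on the sulfonyl sulfur gives a 7.9-fold lower number from compound 2 to compound 4 (0.90 log units; beyond the scatter), while with piperidin-3-yl held fixed, 3,5-dichlorophenyl in place of phenyl gave a 6.3-fold higher number from compound 1 to compound 3 (0.80 log units; beyond the scatter). These two steps run in opposite directions, but they start from different groups on the sulfur and are not the same change, so the 3,5-dichlorophenyl group has no single direction in this short series. Nothing measured here gives a reason for these steps.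

As far as these compounds go, the methyl step rests on a single pair, so whether it holds with phenyl or 3-fluorophenyl on the sulfonyl sulfur remains open. Also open, from the compounds shown here alone, is what ethyl or a longer chain on the same ring nitrogen would do in this assay.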